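Chloro to hydroxymethyl on an aromatic carbon

This account rests on a few compounds, and the source may have more. Where it says the series, first, only, none or still open, it means among the compounds named here.

In a functional assay on the whole organism with Rattus norvegicus as the target (a higher number here means that more compound is needed for the effect, a lower number that less compound is needed), compound 3 (`O=C(O)C(=O)Nc1nc(-c2cc(Cl)no2)cs1`) gives > 30 mg/kg, which is a limit of the assay. Compound 1 (`CCOCCOC(=O)C(=O)Nc1nc(-c2cc(Cl)no2)cs1`) gives > 30 mg/kg, also a limit. Both therefore stand at the limit of > 30 mg/kg in this assay, at which 2 of the 3 values shown sit. Compound 2 (`CCOC(=O)C(=O)Nc1nc(-c2cc(C)no2)cs1`) gives a true number, 0.7 mg/kg.

Compound 4 (`O=C(O)C(=O)Nc1nc(-c2cc(CO)no2)cs1`) arises from compound 3 by hydroxymethyl in place of chloro on an aromatic carbon. Going by the values given here, the only measured step, a step that the two limits leave unreadable from compound 1 to compound 3, offers no size to carry over, so no firm step size or direction can be drawn from the series. The expectation therefore starts from compound 3 at its limit of > 30 mg/kg, and another limit result is thought more likely than not. The expected change, a number no higher from compound 3 to compound 4 (the limit leaves the size open), is an estimate with wide bounds. Compound 4 is estimated at 30 mg/kg, with an expected range of 6 mg/kg to 100 mg/kg.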

Compound 4, dose for half-maximal effect: 0.7 mg/kg
Compound 4: middle estimate off by 43-fold (1.63 log units), on the high side; measured number below the stated range.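

The aromatic carbon next to the ring nitrogen is sensitive to substitution in this assay: hydroxymethyl in place of chloro gives an at least 42-fold lower number from compound 3 to compound 4 (1.63 log units; beyond the scatter). Going by these compounds alone, this is the first readable step at this position, and it shows that a compound with hydrogen on the oxygen next to the carbonyl group can give a true number. Compound 3 stands at a limit, not a true number: the limit of > 30 mg/kg in this assay, at which 2 of the 4 values shown sit.

On these data alone, how methoxymethyl or aminomethyl would read at this position remains open. Also open, as far as these compounds go, is whether hydroxymethyl would give a similar result with an ethyl ester in place of that hydrogen.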